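This account rests on a few compounds, and the source may have more. Where it says the series, first, only, none or still open, it means among the compounds named here.

Series notes.

Measured so far:
compound 1 `Cc1cnc(Nc2ccc3[nH]ncc3c2)nc1-c1ccc(OC(F)(F)F)cc1`: 125 nM
compound 2 `Cc1cnc(Nc2ccc(C(=O)Nc3c(C)cccc3C)cc2)nc1-c1ccccc1OC(F)(F)F`: a limit, > 500 nM
compound 3 `Cc1ccc(-c2nc(Nc3ccc(C(=O)Nc4c(C)cccc4C)cc3)ncc2C)cc1`: a limit, > 500 nM

In an assay on NIH3T3 cells for inhibition of Sonic hedgehog protein (Mus musculus), read by a luciferase reporter, with a stated time of 48 h (on this read-out higher numbers stand for weaker inhibition and lower numbers for stronger inhibition), compound 1 gives 125 nM. Compound 2 gives only a limit in this assay, > 500 nM. Compound 3 likewise gives only a limit, > 500 nM. Compound 2 thus stands at the limit (the limit of > 500 nM in this assay, at which 2 of the 3 values shown sit), and no number is known for it.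

Compound 4 `Cc1cnc(Nc2ccc(C(=O)Nc3c(C)cccc3C)cc2)nc1-c1ccccc1` differs from compound 2 by hydrogen in place of trifluoromethoxy on an aromatic carbon. Among the measured compounds shown here, the only measured step on a related change, a step that the two limits leave unreadable from compound 2 to compound 3, gives no size. For the measured compounds named here, compound 1 differs from compound 2 in more than one place, so its value shows only that a compound of the shared core can reach a number in this assay. Nothing measured therefore sizes the change from compound 2 to compound 4 or gives it a direction beyond the scatter. The expected step is a step that the limit leaves unreadable from compound 2 to compound 4, estimated without a readable direction. Compound 4 is expected at 700 nM, with a range from 250 nM to 2500 nM, and most likely is again reported only as a limit.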

Compound 4, half-maximal inhibitory concentration: 1.3 nM
For compound 4 the middle estimate is 540-fold (2.73 log units) above the measured one; the whole stated range lies above it.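

Hydrogen in place of trifluoromethoxy gives an at least 380-fold lower number from compound 2 to compound 4 (2.58 log units; beyond the scatter) and hydrogen in place of methyl gives an at least 380-fold lower number from compound 3 to compound 4 (2.58 log units; beyond the scatter) in this assay. Among these three compounds, which share the amide side, only compound 4 with its plain phenyl gives a number, so the substituent on this ring matters far more than the earlier compounds could show. Both steps give only minimum sizes because compound 2 and compound 3 stand only at a limit: the limit of > 500 nM in this assay, at which 2 of the 4 values shown sit.

The step from compound 2 to compound 3 cannot be read, so the trifluoromethoxy and methyl groups remain unranked against each other. Going by these compounds, whether fluorine or methoxy on this phenyl keeps the number of compound 4, and whether hydrogen in place of trifluoromethoxy has a like effect on the core of compound 1, remains open.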